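Removing a methoxy from a pyrazoline: an expected step

The source may hold more compounds than are shown below. What is called first, only, known or untested is meant among the compounds shown, and "the series" means these compounds.

Measured compounds:
compound 1 `COc1ccc(OC)c(C2CC(c3ccco3)=NN2C(C)=O)c1`, 11000 nM
compound 2 `COc1cc(OC)c(C2CC(c3ccco3)=NN2C(C)=O)cc1OC`, 6760 nM
compound 3 `COc1ccc(C2CC(c3cccc4ccccc34)=NN2C(C)=O)c(OC)c1OC`, 1980 nM

In a functional assay on OVCAR cells (Homo sapiens) for cytotoxicity, read by sulforhodamine B assay, with a stated time of 48 h (on this read-out higher numbers stand for weaker inhibition and lower numbers for stronger inhibition), compound 3 gives the lowest number of the three. The difference between the core of compound 2 and that of compound 3 is not broken down here. Compound 4 `COc1ccc(C2CC(c3cccc4ccccc34)=NN2C(C)=O)cc1OC` has not yet been measured in this assay. From compound 3 to compound 4 the change is hydrogen in place of methoxy on an aromatic carbon. The same kind of change has already been made once: from compound 2 to compound 1 it is hydrogen in place of methoxy on an aromatic carbon, and that step was a 1.6-fold higher number from compound 2 to compound 1 (0.21 log units; within the scatter). The two places are not the same word for word: in compound 2 the leaving methoxy is para to a large group, in compound 3 it is ortho to a large group. Resting on that earlier step, the number for compound 4 is expected to rise only a little, with an estimated step of a 1.5-fold higher number from compound 3 to compound 4 (0.18 log units; within the scatter). The estimate for compound 4 is 3000 nM, in the range 1200 nM to 8000 nM.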

Compound 4, half-maximal inhibitory concentration: 2690 nM
Compound 4: the middle estimate sits 1.1-fold (0.05 log units) above what was measured, and the stated range covers the measured number.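

Swapping a methoxy for hydrogen on an aromatic carbon gives a 1.4-fold higher number from compound 3 to compound 4 (0.13 log units; within the scatter) in this assay. Set beside the same swap on the other core, the result carries over: the same change on two cores in this assay, a 1.6-fold higher number (0.21 log units; within the scatter) from compound 2 to compound 1 and a 1.4-fold higher number (0.13 log units; within the scatter) from compound 3 to compound 4, 1.2-fold (0.08 log units) apart, within the scatter of two such steps So, for these two cores, neither step can be told apart from repeat-measurement scatter, and the two steps cannot be told apart from each other; two pairs, with the methoxy leaving a different place in each, do not make a rule for other cores or other places.

The compounds shown hold only methoxy or hydrogen at these places. As far as these compounds go, what a hydroxyl group, an amine or a longer chain such as butoxy would do there stays open.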